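Replacing an amide substituent on a shared core

This account rests on a few compounds, and the source may have more. Where it says the series, first, only, none or still open, it means among the compounds named here.

Four compounds sharing one core are compared here. Compound 1 `CC[C@@H](C)[C@H](NC(=O)c1ccc(C(CC)(CC)c2ccc(OCC(=O)C(C)(C)C)c(C)c2)n1CC)C(=O)O` gives 1600 nM in a functional assay on PC-3 cells (Homo sapiens), read by MTT assay, with a stated time of 48 h; a lower number here means a stronger inhibitor, a higher number a weaker inhibitor. Compound 2 `CCn1c(C(=O)N(C)CC(=O)O)ccc1C(CC)(CC)c1ccc(OCC(=O)C(C)(C)C)c(C)c1` differs from it in a single place: (carboxymethyl)(methyl)amino in place of (1-carboxy-2-methylbutyl)amino on a carbonyl carbon This change made a large step, a 12-fold higher number from compound 1 to compound 2 (1.06 log units; beyond the scatter), so compound 2 gives 18400 nM in this assay.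

Compound 3 `CC[C@@H](C)[C@H](NC(=O)c1ccc(C(CC)(CC)c2ccc(OCC(O)C(C)(C)C)c(C)c2)n1CC)C(=O)O` differs from compound 1 elsewhere: 1-hydroxy-2,2-dimethylpropyl in place of (tert-butyl)carbonyl on a saturated chain carbon bound to an oxygen on an aromatic ring The step here is small, a 1.2-fold higher number from compound 1 to compound 3 (0.07 log units; within the scatter), and compound 3 gives 1900 nM in this assay, a number within the usual scatter of that of compound 1.

Compound 4 `CCn1c(C(=O)N(C)CC(=O)O)ccc1C(CC)(CC)c1ccc(OCC(O)C(C)(C)C)c(C)c1` has not yet been measured. It carries the same change relative to compound 3 that compound 2 carries relative to compound 1: (carboxymethyl)(methyl)amino in place of (1-carboxy-2-methylbutyl)amino on a carbonyl carbon The place of the change is described in the same words for both pairs, so it is the same change, made on a core that differs only by the change already described between compound 1 and compound 3.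

Within the data shown here, the expectation for compound 4 rests on the single earlier example: because the same change gave a 12-fold higher number from compound 1 to compound 2 (1.06 log units; beyond the scatter), a step of similar size, a 12-fold higher number from compound 3 to compound 4 (1.06 log units; beyond the scatter), is expected here. That single pair is the only basis, and a weaker core could answer the change differently. Compound 4 is therefore estimated to give 22000 nM in this assay, with the likely range running from 8000 nM to 60000 nM.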

Compound 4, half-maximal inhibitory concentration: 23900 nM
For compound 4 the middle estimate is 1.1-fold (0.04 log units) below the measured one, within the range that was stated.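

Among these compounds, putting (carboxymethyl)(methyl)amino in place of (1-carboxy-2-methylbutyl)amino on the carbonyl carbon again gives a large loss in this assay, a 13-fold higher number from compound 3 to compound 4 (1.10 log units; beyond the scatter), and this step closely matches the one seen earlier: the same change on two cores in this assay, a 12-fold higher number (1.06 log units; beyond the scatter) from compound 1 to compound 2 and a 13-fold higher number (1.10 log units; beyond the scatter) from compound 3 to compound 4, 1.1-fold (0.04 log units) apart, within the scatter of two such steps The other change, 1-hydroxy-2,2-dimethylpropyl in place of (tert-butyl)carbonyl, stays small with the (carboxymethyl)(methyl)amino group in place, a 1.3-fold higher number from compound 2 to compound 4 (0.11 log units; within the scatter), so in these four compounds each change keeps its size whichever form the other site takes: the same change on two cores in this assay, a 1.2-fold higher number (0.07 log units; within the scatter) from compound 1 to compound 3 and a 1.3-fold higher number (0.11 log units; within the scatter) from compound 2 to compound 4, 1.1-fold (0.04 log units) apart, within the scatter of two such steps This shows only that the amide change carries between two closely related cores in one cell assay; it does not show that it would carry to a more different core, and since the swap removes the amide hydrogen, both defined stereocentres and part of the side chain at once, it does not show which of these differences accounts for the step.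

The compounds shown leave open where a (carboxymethyl)amino group, which keeps the amide hydrogen but has no methyl on the nitrogen, would fall on either core. They also leave open how an ester or a primary amide in place of the carboxylic acid would behave in this series.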